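A Phenyl Substituent Swap on the Aryl Ether Oxygen

The source may hold more compounds than are shown below. What is called first, only, known or untested is meant among the compounds shown, and "the series" means these compounds.

For the measured compounds named here, compound 2 `Cc1nn(C)c(Oc2ccc(Cl)cc2)c1/C=N\CCCCCCOc1cc2oc(=O)cc(C)c2cc1Cl` gives 2960 nM in a functional assay on HepG2 cells (Homo sapiens) for antiproliferative activity, read by MTT assay, with a stated time of 72 h (on this read-out lower numbers stand for stronger inhibition and higher numbers for weaker inhibition), the only finite number among the two values shown. Compound 1 `Cc1nn(C)c(Oc2cccc(F)c2)c1/C=N\CCCCCCOc1cc2oc(=O)cc(C)c2cc1Cl` reaches only the limit of the assay, > 25000 nM in this assay. Going by the values given here, the single measured step, an at least 8.4-fold lower number from compound 1 to compound 2 (0.92 log units; beyond the scatter), concerns the same oxygen on an aromatic ring that is changed here, and its size is known only as a bound through (the limit of > 25000 nM in this assay, at which 1 of the 2 values shown sits).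

Compound 3 `Cc1nn(C)c(Oc2cccc(C(F)(F)F)c2)c1/C=N\CCCCCCOc1cc2oc(=O)cc(C)c2cc1Cl` differs from compound 2 by 3-(trifluoromethyl)phenyl in place of 4-chlorophenyl on an oxygen on an aromatic ring. The incoming 3-(trifluoromethyl)phenyl shares its substitution pattern with the 3-fluorophenyl of compound 1, whereas compound 2 carries a 4-chlorophenyl. Among the compounds with values here, the one step measured therefore bears on this change in reverse: moving from a 3-substituted phenyl to a 4-chlorophenyl gave an at least modest drop in the number, so moving back to a 3-substituted phenyl is expected to raise it again, beyond the scatter. Compound 3 is thus estimated at about 10000 nM in this assay, within 3000 nM to 30000 nM, an expected step of a 3.4-fold higher number from compound 2 to compound 3 (0.53 log units; beyond the scatter), with a fair chance that only the limit is recorded.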

Compound 3, half-maximal inhibitory concentration: > 25000 nM
Compound 3: no number, only a limit; the forecaster's own chance of this, stated with the estimate: 40%; middle value at least 2.5-fold (0.39 log units) from the limit.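

In this assay, 3-(trifluoromethyl)phenyl in place of 4-chlorophenyl on this oxygen brings an at least 8.4-fold higher number from compound 2 to compound 3 (0.92 log units; beyond the scatter), a second step at this position whose size is known only as a bound. Among the three aryl ethers shown, the 4-chlorophenyl of compound 2 alone gives a finite number, while the 3-fluorophenyl of compound 1 and the 3-(trifluoromethyl)phenyl of compound 3 both end at a limit; this pattern rests on these three compounds only, and none of them goes against it. The step from fluoro to trifluoromethyl on the aromatic carbon, which links compound 1 and compound 3, cannot be read: the limit of > 25000 nM in this assay, at which 2 of the 3 values shown sit.

The compounds shown leave open whether the finite number of compound 2 follows from the chlorine itself or from where it sits on the phenyl ring, a question that 3-chlorophenyl, 4-fluorophenyl or 4-(trifluoromethyl)phenyl would address. On these data alone, how an unsubstituted phenyl, or a phenyl bearing a methoxy group or an amine, would behave on this oxygen also remains open.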